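Swapping a chloro for a methyl on a cytotoxicity scaffold

A few compounds are considered here, and "the series" means these few. Any claim that something is new, unique, unknown or untested is made for them only; others in the source may bear on it.

Measured compounds:
- compound 1 `COc1ccc(-n2ncn(Cc3cn(Cc4cc5cc(Cl)ccc5nc4Cl)nn3)c2=O)cc1`: 1060 ug/mL
- compound 2 `Cc1cccc2cc(Cn3cc(Cn4cnn(-c5ccccc5)c4=O)nn3)c(Cl)nc12`: 729 ug/mL
- compound 3 `COc1ccc(-n2ncn(Cc3cn(Cc4cc5ccc(Cl)cc5nc4Cl)nn3)c2=O)cc1`: 1470 ug/mL

In an ADME assay on HEK293 cells (Homo sapiens) for cytotoxicity, read by MTT assay (a higher number here means a weaker inhibitor, a lower number a stronger inhibitor), compound 1 gives 1060 ug/mL. Compound 3 gives 1470 ug/mL and compound 2 gives 729 ug/mL in this assay. Compound 1 sits second highest of the three numbers, but its gap to compound 3 and its gap to compound 2 both lie within the usual scatter of repeated measurements, so the three values cannot be told apart.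

The next compound, compound 4 `COc1ccc(-n2ncn(Cc3cn(Cc4cc5cc(C)ccc5nc4Cl)nn3)c2=O)cc1`, has not yet been tested. It differs from compound 1 in one place: methyl in place of chloro on an aromatic carbon. Going by the values given here, no measured pair in this set shows the effect of such a swap, so there is no direct guide.

Given how close the three known numbers sit, the step from compound 1 to compound 4 is expected to be no more than the scatter, in no particular direction: a 1.0-fold higher number from compound 1 to compound 4 (0.02 log units; within the scatter). Compound 4 is therefore expected to give about 1100 ug/mL in this assay, within a range from 600 ug/mL to 2000 ug/mL.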

Compound 4, half-maximal inhibitory concentration: 615 ug/mL
Compound 4: the middle estimate sits 1.8-fold (0.25 log units) above what was measured, and the stated range covers the measured number.
By their numbers in this assay, from the lowest: compounds 4, 2, 1 and 3 (each within the scatter of the next, the first and the last beyond it).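

In this assay, this position now has its first direct test, a swap of methyl in place of chloro on an aromatic carbon: a 1.7-fold lower number from compound 1 to compound 4 (0.24 log units; within the scatter). One heavy atom replaces another here, with no ring, hydrogen-bond donor, hydrogen-bond acceptor or net charge on either side of the swap, and this single step does not separate the two compounds beyond the usual scatter. Nothing available explains the size of this step or says what either group does in these cells.

The compounds shown leave open whether a quite different group at this position, such as an amine, a carboxylic acid or a longer chain, would give a step beyond the scatter. As far as these compounds go, it is also open whether the same swap would give a similar step on compound 3, whose chloro sits elsewhere on the shared core.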